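Working notes on cytotoxicity across four compounds

This account rests on a few compounds, and the source may have more. Where it says the series, first, only, none or still open, it means among the compounds named here.

Measured so far:
Compound 1, `CC(=O)c1cccc(-c2ccc(C(=O)N(Cc3cccc(OCCCCCC(=O)O)c3)C(C)C)cc2)c1`, in an ADME assay on HepG2 cells (Homo sapiens) for cytotoxicity, read by CellTiter-Glo and resazurin assay, with a stated time of 72 h (a higher number here means that more compound is needed for the effect, a lower number that less compound is needed), gives > 26000 nM, which is a limit of the assay.
Compound 2, `CC(C)COc1cccc(-c2ccc(C(=O)N(Cc3cccc(OCCCCCC(=O)O)c3)C(C)C)cc2)c1`, in this assay gives > 26000 nM, also a limit.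
Compound 3, `CCOC(=O)CCCCCOc1cccc(CN(C(=O)c2ccc(-c3cccc(C(C)=O)c3)cc2)C(C)C)c1`, in this assay gives > 26000 nM, again a limit.

The change from compound 1 to compound 2 is isobutoxy in place of acetyl on an aromatic carbon. Its step, a step that the two limits leave unreadable from compound 1 to compound 2, cannot be sized since (the limit of > 26000 nM in this assay, at which 3 of the 3 values shown sit). The cores of compound 1 and compound 3 differ by ethyl in place of hydrogen on an oxygen next to a carbonyl group, and the step that the two limits leave unreadable from compound 1 to compound 3 is likewise unreadable. Compound 4, `CCOC(=O)CCCCCOc1cccc(CN(C(=O)c2ccc(-c3cccc(OCC(C)C)c3)cc2)C(C)C)c1`, is not yet measured. It differs from compound 3 by isobutoxy in place of acetyl on an aromatic carbon, the same change as from compound 1 to compound 2, with the place described in identical words. In this assay compound 4 is expected to stay at the limit, a step that the limit leaves unreadable from compound 3 to compound 4. This expectation rests on compound 2, which gives > 26000 nM. Compound 4 is thus estimated at 40000 nM, between 20000 nM and 120000 nM, most likely reported only as a limit.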

Compound 4, half-maximal effective concentration: > 26000 nM
Compound 4 gave a limit, no number; the forecaster's own chance of this, stated with the estimate: 85%; the middle value does not contradict the limit.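

Compound 4 is also only a limit, so no step from compound 2 or compound 3 to compound 4 can be read in this assay: the limit of > 26000 nM in this assay, at which 4 of the 4 values shown sit.

The compounds shown leave open whether either change, isobutoxy in place of acetyl or ethyl in place of hydrogen, alters the concentration needed for the effect in this assay.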